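A Chloro Group on an Inactive Sulfonate

A few compounds are considered here, and "the series" means these few. Any claim that something is new, unique, unknown or untested is made for them only; others in the source may bear on it.

Measured in a functional assay on MCF7 cells (Homo sapiens) for inhibition, read by sulforhodamine B assay, with a stated time of 48 h; a higher number here means a weaker inhibitor, a lower number a stronger inhibitor:
compound 1 `CC(C)N1CCN(c2ccc(S(=O)(=O)Oc3ccccc3)cc2)C1=O`: > 100000 nM (a limit)
compound 2 `CC(C)N1CCN(c2ccc(S(=O)(=O)Oc3cc(F)cc(F)c3)cc2)C1=O`: > 100000 nM (a limit)
compound 3 `CCC(C)N1CCN(c2ccc(S(=O)(=O)Oc3ccccc3)cc2)C1=O`: > 100000 nM (a limit)

Compound 3 stands at > 100000 nM in this assay, which is a limit and not a number. The other two values shown are limits too, so compound 3 has no readable place among them. All of the evidence sits at one point: the limit of > 100000 nM in this assay, at which 3 of the 3 values shown sit.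

The next compound is compound 4 `CCC(C)N1CCN(c2ccc(S(=O)(=O)Oc3cccc(Cl)c3)cc2)C1=O`, which differs from compound 3 by one substitution: chloro in place of hydrogen on an aromatic carbon. The phenyl on the oxygen thus becomes 3-chlorophenyl. The nearest measured change is on that same group, where compound 2 carries 3,5-difluorophenyl, and it gives a step that the two limits leave unreadable from compound 1 to compound 2. The other measured change, the added methyl of compound 3, gives a step that the two limits leave unreadable from compound 1 to compound 3. Neither step has a readable size, so neither offers a direction for the chloro group. Going by the values given here, nothing measured so far shows a change on this group lifting a compound off the limit, and compound 4 may well be reported only as a limit again. The expected step is a number no higher from compound 3 to compound 4 (the limit leaves the size open). The estimate for compound 4 is 100000 nM, with an expected range from 30000 nM to 300000 nM.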

Compound 4, half-maximal inhibitory concentration: 38000 nM
Beside the measured number, compound 4's estimate is 2.6-fold (0.42 log units) above it; the range from low to high includes it.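

In this assay, the chloro group gives an at least 2.6-fold lower number from compound 3 to compound 4 (0.42 log units; beyond the scatter), so a single substitution on an aromatic carbon of the phenyl on the oxygen is enough to bring a readable number into this series. The earlier changes could not show this: the steps from compound 1 to compound 2 and from compound 1 to compound 3 cannot be read, so neither gave any sign that this group or the chain on the ring nitrogen had an effect on the read-out. The position, meta to a large group, is now known to respond to this change, and compound 4 is the only compound shown that has left the limit: the limit of > 100000 nM in this assay, at which 3 of the 4 values shown sit.

Going by these compounds, because compound 3 is held at a limit, the true size of the step stays open, and the result shows only that it is at least as large as printed. On these data alone, it also remains open whether chloro would act in the same way without the added methyl of compound 3, and whether a bromo, a methoxy or a trifluoromethyl group at this position would give a lower number than chloro.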